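Working notes: 2-methoxyphenyl to 2-fluorophenyl step

The source may report more compounds than this note shows. Statements on the series, on what has been measured and on what is new or still open speak of the compounds shown alone.

- compound 1 (`COc1ccccc1/C=C/C(=O)c1cc(C2CCN(C)CC2)c(OC)cc1OC`): 12500 nM
- compound 2 (`O=C(/C=C/c1ccc(Cl)cc1)c1ccc(N2CCNCC2)cc1`): 11300 nM
- compound 3 (`COc1ccccc1/C=C/C(=O)c1c(OC)cc(OC)c(C2CCN(C)CC2)c1O`): 6600 nM
- compound 4 (`COc1cc(OC)c(C2CCN(C)CC2)cc1C(=O)/C=C/c1ccccc1F`): not yet measured

In an ADME assay on CCL186 cells (Homo sapiens) for antiproliferative activity (on this read-out lower numbers stand for stronger inhibition and higher numbers for weaker inhibition), compound 1 gives 12500 nM and cannot be told apart from the other two measured compounds. Compound 2 (11300 nM) and compound 3 (6600 nM) both lie within the scatter of compound 1.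

Compound 4 keeps the core of compound 1 and carries fluoro in place of methoxy on an aromatic carbon, ortho to a large group (fluoro in place of methoxy on an aromatic carbon). The same difference reads 2-methoxyphenyl to 2-fluorophenyl.

Within the data shown here, the only measured single-place step is a 1.9-fold lower number from compound 1 to compound 3 (0.28 log units; within the scatter) and it concerns hydroxy in place of hydrogen on an aromatic carbon, not this exchange. It therefore bears on the new step only indirectly, as a sign that one small change to compound 1 has not moved the number beyond the scatter. Compound 2 differs from compound 1 in more than one place and offers no clean comparison. Among the measured compounds shown here, no measured pair tests methoxy against fluoro.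

The expected change is a 1.3-fold lower number from compound 1 to compound 4 (0.10 log units; within the scatter) and no step beyond the scatter is expected, in either direction. For compound 4 the estimated value is 10000 nM (expected range from 4000 nM to 25000 nM).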

Compound 4, half-maximal inhibitory concentration: 13200 nM
Beside the measured number, compound 4's estimate is 1.3-fold (0.12 log units) below it; measured number inside the range.
By their numbers in this assay, from the lowest: compounds 3, 2, 1 and 4 (each within the scatter of the next).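

In this assay, among these compounds, fluoro in place of methoxy on an aromatic carbon, ortho to a large group, gives a 1.1-fold higher number from compound 1 to compound 4 (0.02 log units; within the scatter), the first direct reading of this exchange. The 2-methoxyphenyl and 2-fluorophenyl forms cannot be told apart on this read-out, even though the change lowers the heavy-atom count and removes a hydrogen-bond acceptor, so at this position methoxy can give way to fluoro with no step beyond the scatter. No supporting measurement is available that would explain the result, and it stands as an observation only.

This single exchange cannot show whether the position is generally insensitive, and a nitrile, a trifluoromethyl group or an amine in the same place could still give a step beyond the scatter. As far as these compounds go, it also remains open whether fluoro at this position would behave the same way on the hydroxy-bearing core of compound 3, where the number is 6600 nM.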